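A few compounds are considered here, and "the series" means these few. Any claim that something is new, unique, unknown or untested is made for them only; others in the source may bear on it.

Measured so far, in a functional assay on MDA-MB-231 cells (Homo sapiens) for cytotoxicity, read by MTT assay, with a stated time of 48 h; a lower number here means a stronger inhibitor, a higher number a weaker inhibitor:
Compound 1, `Cc1ccsc1CN(C(=O)Nc1ccccc1)n1cnnc1`, gives > 50000 nM, which is a limit of the assay and not a number.
Compound 2, `O=C(Nc1ccccc1)N(Cc1ccccn1)n1cnnc1`, gives > 50000 nM, again a limit rather than a number.
Compound 3, `N#Cc1ccc(CN(C(=O)Nc2ccccc2)n2cnnc2)cc1`, gives > 50000 nM, also a limit.

All three compounds share a core that differs only in the group on the saturated chain carbon bound to the amide-type nitrogen. Compound 1 stands at the limit, so no real number places it. The steps a step that the two limits leave unreadable from compound 1 to compound 2 and a step that the two limits leave unreadable from compound 1 to compound 3 cannot be sized, since both ends of each sit at the limit of > 50000 nM in this assay, at which 3 of the 3 values shown sit.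

Compound 4, `Cc1ccsc1CN(C(=O)Nc1cccc(Cl)c1)n1cnnc1`, is reached from compound 1 by a different kind of change: chloro in place of hydrogen on an aromatic carbon. Within the data shown here, no measured step touches this part of the molecule, so nothing in the data shows whether such a change moves the value. Among the measured compounds shown here, the only guide is that every measured compound sits at the limit.

Compound 4 is therefore expected to sit at the limit as well, estimated at 50000 nM with a range from 20000 nM to 120000 nM, meaning an expected step of a number no higher from compound 1 to compound 4 (the limit leaves the size open), none beyond the scatter.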

Compound 4, half-maximal inhibitory concentration: 40300 nM
For compound 4 the middle estimate is 1.2-fold (0.09 log units) above the measured one; measured number inside the range.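

Among these compounds, the change from phenyl to 3-chlorophenyl is the first in this part of the molecule, on an aromatic carbon of a six-membered aromatic ring of carbon only, and in this assay it gives an at least 1.2-fold lower number from compound 1 to compound 4 (0.09 log units; that floor lies within the scatter). Going by these compounds, the value of compound 1 is a limit and not a number, so that step is only a floor and its true size stays unknown. Compound 4 is the only compound shown with a real number, which is the one new thing here, as all the others sit at the limit: the limit of > 50000 nM in this assay, at which 3 of the 4 values shown sit.

The compounds shown leave open whether fluoro, methyl or methoxy in the same place would also give a real number, and whether chloro on another carbon of that ring would. They also leave open whether the same chloro would give a real number on compound 2 or compound 3.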